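Methoxy-methylphenyl Replaces Methoxymethylphenyl in a Weak Series

The compounds below may be only part of what the source reports. "The series", "measured", "known", "first", "only" and "open" are said of these compounds alone.

Of the compounds shown here, three sharing one core have been measured in a functional assay on KB cells (Homo sapiens) for antiproliferative activity, read by sulforhodamine B assay, with a stated time of 3 days; on this read-out higher numbers stand for an effect only at larger amounts of compound and lower numbers for an effect already at smaller amounts. Compound 1 `CCCOc1ccc(-c2cc(=O)c3c(o2)C(CC)(CC)C(=O)C(CC)=C3O)cc1` carries a propoxy group on its pendant aromatic ring; in this assay compound 1 reaches only a limit, > 50.5 uM. Compound 2 `CCC1=C(O)c2c(oc(-c3ccc(OC(F)(F)F)cc3)cc2=O)C(CC)(CC)C1=O` bears a trifluoromethoxy group instead, and in this assay compound 2 gives 36.5 uM. Compound 3 `CCC1=C(O)c2c(oc(-c3ccc(COC)cc3)cc2=O)C(CC)(CC)C1=O` has a methoxymethyl group on that ring; in this assay compound 3 again reaches only a limit, > 52.4 uM, so its standing is marked by the limit of > 52.4 uM in this assay, at which 1 of the 3 values shown sits, rather than by a number. The steps to compound 3 are therefore thin: a step that the two limits leave unreadable from compound 1 to compound 3, and an at least 1.4-fold higher number from compound 2 to compound 3 (0.15 log units; that floor lies within the scatter).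

Compound 4 `CCC1=C(O)c2c(oc(-c3ccc(OC)c(C)c3)cc2=O)C(CC)(CC)C1=O` changes the pendant ring once more: 4-methoxy-3-methylphenyl in place of 4-(methoxymethyl)phenyl on an aromatic carbon. Among the compounds with values here, no measured step involves a 4-methoxy-3-methylphenyl group, so none bears directly on this change; what the series shows is that two of three values sit at limits (the limit of > 50.5 uM in this assay, at which 1 of the 3 values shown sits, (the limit of > 52.4 uM in this assay, at which 1 of the 3 values shown sits)) and the one number, for compound 2, is itself large. The step from compound 3 to compound 4 is thus expected to be small or unreadable, an at least 1.1-fold lower number from compound 3 to compound 4 (0.06 log units; that floor lies within the scatter), with a limit again likely. In this assay compound 4 is estimated at 45 uM, within a range from 18 uM to 110 uM.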

Compound 4, concentration for half-maximal effect: 28.5 uM
Beside the measured number, compound 4's estimate is 1.6-fold (0.20 log units) above it; the measured number falls inside the stated range.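

The change from 4-(methoxymethyl)phenyl to 4-methoxy-3-methylphenyl keeps the same heavy atoms on the pendant ring but joins them differently, and it gives an at least 1.8-fold lower number from compound 3 to compound 4 (0.26 log units; that floor lies within the scatter) in this assay. As far as these compounds go, compound 4 thus has a readable number where compound 3 has none, although the printed floor does not establish a step beyond the scatter, and the true size of the step stays unknown. Compound 3 is still represented only by a limit, not a number: the limit of > 52.4 uM in this assay, at which 1 of the 4 values shown sits.

The compounds shown do not separate the two parts of this change, so it remains open whether the oxygen bound directly to the pendant ring, the methyl group on that ring, or the two together account for the number seen with compound 4. From the compounds shown here alone, it is also open how the read-out would respond to a plain 4-methoxyphenyl group, to a longer alkoxy chain alongside the methyl group, or to an amine or a carboxylic acid on the same ring.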